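The source may hold more compounds than are shown below. What is called first, only, known or untested is meant among the compounds shown, and "the series" means these compounds.

Measured in a functional assay on HeLa cells (Homo sapiens) for cytotoxicity, read by MTT assay; on this read-out lower numbers stand for stronger inhibition and higher numbers for weaker inhibition:
- Compound 1 `CCCCC(CC(=O)O[C@H](CC=C(C)C)C1=CC(=O)c2c(O)ccc(O)c2C1=O)OC(C)=O`: 73500 nM
- Compound 2 `CC(C)=CC[C@@H](OC(=O)CC(C)(O)C(C)C)C1=CC(=O)c2c(O)ccc(O)c2C1=O`: 27700 nM
- Compound 3 `CCCC(C)(O)CC(=O)O[C@H](CC=C(C)C)C1=CC(=O)c2c(O)ccc(O)c2C1=O`: 72000 nM

Compound 3, at 72000 nM, cannot be told apart from compound 1, with a 1.0-fold lower number from compound 1 to compound 3 (0.01 log units; within the scatter). Compound 2 gives the lowest number of the three, and the gap to it is a 2.6-fold higher number from compound 2 to compound 3 (0.41 log units; beyond the scatter).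

The next compound is compound 4 `CCCCC(C)(O)CC(=O)O[C@H](CC=C(C)C)C1=CC(=O)c2c(O)ccc(O)c2C1=O`, which differs from compound 3 in one place: methyl in place of hydrogen on a saturated chain carbon, four bonds along the chain from an oxygen on a saturated carbon. The same difference, read one bond further out, is propyl to butyl.

Going by the values given here, two measured steps bear on this change, though neither is the same change. The step with propyl in place of isopropyl is modest, at a 2.6-fold higher number from compound 2 to compound 3 (0.41 log units; beyond the scatter). The exchange of 1-acetoxypentyl for 1-hydroxy-1-methylbutyl shows no real change, with a 1.0-fold lower number from compound 1 to compound 3 (0.01 log units; within the scatter). Among the compounds with values here, no measured pair shows the effect of lengthening this straight chain alone, so the evidence is indirect. The modest step involves a branched chain, while the two compounds without that branch sit together. Going by these compounds, no step beyond the scatter is therefore expected in this assay, and the direction remains open.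

The expected step is a 1.1-fold lower number from compound 3 to compound 4 (0.04 log units; within the scatter).

For compound 4 the estimate is 65000 nM, with an expected range of 28000 nM to 130000 nM.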

Compound 4, half-maximal inhibitory concentration: 60600 nM
Compound 4: the middle estimate sits 1.1-fold (0.03 log units) above what was measured; the range from low to high includes it.
By their numbers in this assay, from the lowest: compound 2; then compounds 4, 3 and 1 (each within the scatter of the next).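

In this assay, going by these compounds alone, the change from propyl to butyl gives the first direct reading of lengthening this straight chain alone, with methyl in place of hydrogen four bonds along the chain from an oxygen on a saturated carbon (a 1.2-fold lower number from compound 3 to compound 4 (0.07 log units; within the scatter)). At this position the added methyl therefore leaves no difference that can be told from the scatter. The wider comparisons keep the same shape: exchanging 1-acetoxypentyl for 1-hydroxy-1-methylpentyl shows no real change (a 1.2-fold lower number from compound 1 to compound 4 (0.08 log units; within the scatter)), whereas butyl in place of isopropyl is a modest step (a 2.2-fold higher number from compound 2 to compound 4 (0.34 log units; beyond the scatter)), so compound 2 alone stands apart from the other three. Nothing available accounts for either the flat step along the straight chain or the separate place of compound 2. The compounds shown leave open whether a longer chain such as hexyl, or a butyl chain ending in an amine or a carboxylic acid, would read the same at this position, and whether another branched group such as tert-butyl would stand with compound 2.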